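The source may report more compounds than this note shows. Statements on the series, on what has been measured and on what is new or still open speak of the compounds shown alone.

Measured in a functional assay on HCT-116 cells (Homo sapiens) for inhibition, read by colorimetric assay, with a stated time of 3 days; on this read-out higher numbers stand for weaker inhibition and lower numbers for stronger inhibition:
- compound 1 `O=C(CCCCCCNC(=O)C(O)(O)C(F)(F)F)Nc1ncc(-c2ccc(O)cc2)s1`: 1020 nM
- compound 2 `O=C(CCCCCCNC(=O)C(O)(O)C(F)(F)F)Nc1ncc(-c2ccccc2)s1`: 2660 nM

Of these two, compound 2 has the higher number, 2660 nM, so it is the weaker inhibitor. Compound 3 `O=C(CCCCCCNC(=O)C(O)(O)C(F)(F)F)Nc1nccs1` has not yet been measured. It is compound 2 with hydrogen in place of phenyl on an aromatic carbon, next to the ring sulfur: hydrogen in place of phenyl on an aromatic carbon.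

Within the data shown here, one measured step bears on this: a 2.6-fold higher number from compound 1 to compound 2 (0.42 log units; beyond the scatter). This modest step, beyond the scatter, puts hydrogen in place of hydroxy on an aromatic carbon, and it touches only a small part of the phenyl that compound 3 lacks altogether. Among the measured compounds shown here, no measured step removes the whole phenyl, so this guide is indirect and the uncertainty is wide. In this assay, the expected change is a 2.6-fold higher number from compound 2 to compound 3 (0.42 log units; beyond the scatter), towards weaker inhibition. For compound 3, the estimated value is 7000 nM, with an expected range of 2500 nM to 25000 nM.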

Compound 3, half-maximal inhibitory concentration: 10800 nM
Compound 3: the middle estimate sits 1.5-fold (0.19 log units) below what was measured; measured number inside the range.
By their numbers in this assay, from the lowest: compound 1; then compound 2; then compound 3.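

In this assay, replacing the whole phenyl with hydrogen, on the aromatic carbon next to the ring sulfur, gives a 4.1-fold higher number from compound 2 to compound 3 (0.61 log units; beyond the scatter), towards weaker inhibition. The earlier pair showed only that the hydroxy on the phenyl matters; this result shows that the phenyl itself matters too, since inhibition falls further once the ring is gone. Removing the full 4-hydroxyphenyl gives an 11-fold higher number from compound 1 to compound 3 (1.02 log units; beyond the scatter), the only step among these compounds printed as large, so this position carries much of the difference in inhibition across the series.

As far as these compounds go, it remains open whether something smaller than phenyl, such as a methyl or a chlorine atom, would keep part of the inhibition at this carbon, or how an amine or a carboxylic acid in place of the hydroxy would compare. Nothing available here explains why these changes weaken inhibition.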